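The compounds below may be only part of what the source reports. "The series", "measured", "known", "first", "only" and "open" are said of these compounds alone.

Working notes on the series. Of the compounds shown here, three have been measured in a functional assay on MCF7 cells (Homo sapiens) for antiproliferative activity, read by MTT assay, with a stated time of 48 h; a lower number here means a stronger inhibitor, a higher number a weaker inhibitor. Compound 1 `Cc1ccc(-c2nc3ccc(Cl)cc3c(=S)[nH]2)cc1` gives 3.35 ug/mL in this assay. Compound 3 `Cc1ccc(C(=O)Nc2ccc(Cl)cc2C(=S)NN)cc1` gives 3.35 ug/mL in this assay. Compound 2 `Cc1ccc(-c2nc(NO)c3cc(Cl)ccc3n2)cc1`, which carries the hydroxyamino group on the fused core, gives 6.81 ug/mL in this assay, the highest number of the three; its gap to compound 1 and its gap to compound 3 are each beyond the usual scatter, so compound 2 stands as the weakest inhibitor of the set measured so far.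

Compound 4 `Cc1ccc(-c2nc(SCCO)c3cc(Cl)ccc3n2)cc1` differs from compound 2 in one place: (2-hydroxyethyl)sulfanyl in place of hydroxyamino on an aromatic carbon. Going by the values given here, no measured pair in the set shares this change, so there is no measured step to draw on, and the only context is that compound 2 sits apart from compound 1 and compound 3 in this assay. With nothing more to go on, a step of small size is expected for compound 4 in this assay, in either direction and not beyond the scatter. Compound 4 is estimated at 5.5 ug/mL in this assay, with a range from 2.5 ug/mL to 12 ug/mL. The step this estimate means, a 1.2-fold lower number from compound 2 to compound 4 (0.09 log units; within the scatter), is expected to remain within the scatter.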

Compound 4, half-maximal inhibitory concentration: 3.76 ug/mL
For compound 4 the middle estimate is 1.5-fold (0.17 log units) above the measured one; the range from low to high includes it.
By their numbers in this assay, from the lowest: compounds 1, 3, 4 and 2 (each within the scatter of the next, the first and the last beyond it).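

In this assay, placing (2-hydroxyethyl)sulfanyl instead of hydroxyamino on this aromatic carbon, next to the ring nitrogen, gives a 1.8-fold lower number from compound 2 to compound 4 (0.26 log units; within the scatter) as the first step read at this position. The position therefore accommodates a group of 4 heavy atoms with 1 hydrogen-bond donor in place of one of 2 heavy atoms with 2 hydrogen-bond donors, without a change beyond the scatter, so this read-out does not separate the two groups. No measurement bears on the reason for this result.

This single step leaves open whether the hydroxyl at the end of the chain contributes anything, which a comparison with plain ethylsulfanyl on the same carbon would address. It also leaves open whether the same flat picture would hold for different groups at this position, such as a primary amine, a carboxylic acid or a longer chain such as (4-hydroxybutyl)sulfanyl.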